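A Bromopyridyl Hydrazone Replaces the Catechol-like Group

This account rests on a few compounds, and the source may have more. Where it says the series, first, only, none or still open, it means among the compounds named here.

Of the compounds shown here, three of a shared core have been measured in an assay on CHO-K1 cells for displacement of a labelled ligand from adenosine receptor A1 (Homo sapiens), read by scintillation counting, with a stated time of 60 min; on this read-out higher numbers stand for weaker inhibition and lower numbers for stronger inhibition. Compound 1 `Nc1nc(N/N=C/c2ccc(-c3ccc(Br)cc3)o2)nc2c1ncn2[C@@H]1O[C@H](CO)[C@@H](O)[C@H]1O` gives 4.5 nM in this assay. Compound 2 `Nc1nc(N/N=C/c2cccc(OCc3ccccc3)c2)nc2c1ncn2[C@@H]1O[C@H](CO)[C@@H](O)[C@H]1O` gives 13 nM. Compound 3 `CCOc1cc(/C=N/Nc2nc(N)c3ncn([C@@H]4O[C@H](CO)[C@@H](O)[C@H]4O)c3n2)ccc1O` gives 6940 nM, the highest number of the three; both other compounds sit far below it, compound 2 nearest and compound 1 furthest, and each gap lies beyond the scatter. Compound 3 is thus the weakest binder among the measured set. It is also the only one of the three that carries a 3-ethoxy-4-hydroxyphenyl group on the hydrazone carbon, whereas compounds 1 and 2 carry aryl groups without a hydroxyl there.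

The next compound, compound 4 `Nc1nc(N/N=C/c2ccc(Br)cn2)nc2c1ncn2[C@@H]1O[C@H](CO)[C@@H](O)[C@H]1O`, differs from compound 3 in one place: 5-bromopyridin-2-yl in place of 3-ethoxy-4-hydroxyphenyl on a carbon with a double bond to nitrogen. The entering group, like those of compounds 1 and 2, has no hydroxyl. Going by the values given here, no measured pair with exactly this exchange exists, so the size of the step is open. Still, given the wide gap between compound 3 and the two hydroxyl-free compounds 1 and 2, a large downward step in this assay is expected, a 170-fold lower number from compound 3 to compound 4 (2.24 log units; beyond the scatter). Compound 4 is estimated to give about 40 nM, within a range from 8 nM to 250 nM.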

Compound 4, inhibition constant: 4.7 nM
Beside the measured number, compound 4's estimate is 8.5-fold (0.93 log units) above it; measured number below the stated range.
By their numbers in this assay, from the lowest: compounds 1 and 4 (each within the scatter of the next); then compound 2; then compound 3.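

Going by these compounds alone, exchanging 3-ethoxy-4-hydroxyphenyl for 5-bromopyridin-2-yl on a carbon with a double bond to nitrogen gives a 1500-fold lower number from compound 3 to compound 4 (3.17 log units; beyond the scatter) in this assay and so puts a size on a single change at this position for the first time. The entering group has fewer heavy atoms than the group it replaces and no hydrogen-bond donor, yet the number does not stay near that of compound 3. Compound 4 at 4.7 nM lies within the scatter of compound 1 at 4.5 nM and so shows that one substituted six-membered ring on this carbon can reach the level compound 1 reaches with its larger group.

The exchange removes the hydroxyl and the ethoxy and brings in the ring nitrogen and the bromine all at once, so the compounds shown do not tell which of these carries the step, and a plain phenyl or a 5-chloropyridin-2-yl group on the same carbon would begin to separate them. Nothing at hand explains why the step is so large.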